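A Bromine on the Phenoxy Ring of a Reductase Inhibitor

The source may hold more compounds than are shown below. What is called first, only, known or untested is meant among the compounds shown, and "the series" means these compounds.

Compound 1 `NC1=NC2(CCSCC2)N(OCCCOc2ccc(Cl)c(Cl)c2)C(N)=N1` shows what this series can reach: in an assay on isolated protein for inhibition of Dihydrofolate reductase (Homo sapiens), read by spectrophotometry, using NADPH, with stated times of 5 s and 6 min, tested at 50 uM (a higher number here means a stronger effect of the compound at the concentration tested, a lower number a weaker effect), compound 1 gives 89.8%. Compound 2 `NC1=NC2(CCOCC2)N(OCCCOc2ccccc2)C(N)=N1` carries an unsubstituted phenoxy group on an oxygen-containing core; in this assay compound 2 gives "not determined" (no result reported), so no single number places it on the scale. Compound 3 `NC1=NC2(CCOCC2)N(OCCCOc2cccc(Br)c2)C(N)=N1` differs from compound 2 in one place: bromo in place of hydrogen on an aromatic carbon, the bromo sitting on an aromatic carbon of a six-membered aromatic ring of carbon only, meta to a large group. With no number for compound 2, neither the size nor the direction of the step to compound 3 in this assay can be fixed, and any expectation rests on compound 1 alone. Because compound 1 with its halogenated phenoxy group gives 89.8% in this assay, compound 3 is expected to give 84% in this assay, within a range from 62% to 97%.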

Compound 3, a percentage reported as inhibition, at one concentration (the size of the read-out at that concentration, not a potency): 85.8%
Compound 3: the middle estimate sits 1.8 percentage points below what was measured, within the range that was stated.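

In this assay, among these compounds, compound 3 gives 85.8% while compound 2 has no single number, so no step between the two can be read. The compounds shown leave open what the bromo itself adds to the effect, and no evidence bears on this result.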